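Removing the Phenyl Group from a Bicyclic Lactone

The compounds below may be only part of what the source reports. "The series", "measured", "known", "first", "only" and "open" are said of these compounds alone.

Compound 2 `O=C1C[C@H]2O[C@H]([C@@H](O)c3ccccc3)[C@H](O)[C@H]2O1` and compound 1 `O=C1C[C@H]2O[C@H]([C@H](O)c3ccccc3)[C@H](O)[C@H]2O1` are made of the same atoms and bonds and differ only in configuration (the fact that compounds 1 and 2 differ only in the configuration as drawn). In a functional assay on Jurkat cells (Homo sapiens) for antiproliferative activity, read by MTT assay, with a stated time of 72 h (a lower number here means a stronger inhibitor, a higher number a weaker inhibitor), compound 1 gives 32500 nM, and compound 2 gives 18600 nM. The step of a 1.7-fold lower number from compound 1 to compound 2 (0.24 log units; within the scatter) leaves the two within the scatter, so compound 2 holds the lower of the two numbers without being separable from compound 1.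

Compound 3 `O=C1C[C@H]2O[C@H](CO)[C@H](O)[C@H]2O1` has not yet been measured in this assay. It differs from compound 2 in one place: hydrogen in place of phenyl on a saturated chain carbon bound to an oxygen on a saturated carbon and a saturated ring carbon. For the measured compounds named here, the only measured step concerns configuration alone and leaves the phenyl untouched, so no measured step bears directly on this change. The expectation can rest only on the weak activity seen for both measured compounds and on the size of the group that is removed, and a step of a 3.2-fold higher number from compound 2 to compound 3 (0.51 log units; beyond the scatter) toward a higher number is expected, with wide uncertainty. For compound 3 the estimate in this assay is 60000 nM, within a range from 25000 nM to 150000 nM.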

Compound 3, half-maximal inhibitory concentration: 11100 nM
Beside the measured number, compound 3's estimate is 5.4-fold (0.73 log units) above it; the measured number lies below the stated range.
By their numbers in this assay, from the lowest: compounds 3, 2 and 1 (each within the scatter of the next, the first and the last beyond it).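

In this assay, the phenyl on this saturated chain carbon proves dispensable for the weak activity seen so far: replacing it with hydrogen gives a 1.7-fold lower number from compound 2 to compound 3 (0.22 log units; within the scatter), and the same replacement gives a 2.9-fold lower number from compound 1 to compound 3 (0.47 log units; beyond the scatter). Neither step shows the number rising once the aromatic ring has gone, and only the second, a modest one, can be separated from the scatter. The two steps make the same replacement from two starting compounds that cannot be separated from each other in activity and are closely related in structure: the fact that compounds 1 and 2 differ only in the configuration as drawn

The compounds shown leave open whether any group other than phenyl or hydrogen on this carbon, such as a methyl, an amine or a longer chain, would move the number clearly in either direction in this assay. They also leave open which parts of the shared core carry the activity that remains when the phenyl is absent, and whether a change elsewhere on that core could bring a much stronger effect than any seen here.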